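Sulfonamide aryl variation in an antiproliferative cyclic series

A few compounds are considered here, and "the series" means these few. Any claim that something is new, unique, unknown or untested is made for them only; others in the source may bear on it.

Measured compounds:
compound 1 `CN(c1ccccc1)S(=O)(=O)C1CC2OC1C(c1ccc(NC(=O)CCCCCCC(=O)O)cc1)=C2c1ccc(O)cc1` – 63800 nM
compound 2 `CN(c1ccccc1Cl)S(=O)(=O)C1CC2OC1C(c1ccc(NC(=O)CCCCCCC(=O)O)cc1)=C2c1ccc(O)cc1` – 12800 nM

In a functional assay on MCF7 cells (Homo sapiens) for antiproliferative activity, read by MTT assay, with a stated time of 72 h (on this read-out lower numbers stand for stronger inhibition and higher numbers for weaker inhibition), compound 2 gives 12800 nM, the lowest of the two numbers measured. Among the compounds with values here, its nearest neighbour is compound 1, which gives 63800 nM, and the single step between them, a 5.0-fold lower number from compound 1 to compound 2 (0.70 log units; beyond the scatter), lies beyond the scatter.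

Compound 3 `CCN(c1cccc(OC)c1)S(=O)(=O)C1CC2OC1C(c1ccc(NC(=O)CCCCCCC(=O)O)cc1)=C2c1ccc(O)cc1` has not been measured. It differs from compound 2 in one place: ethyl(3-methoxyphenyl)amino in place of (2-chlorophenyl)(methyl)amino on a sulfonyl sulfur. Within the data shown here, only the step from compound 1 to compound 2 bears on this change, and it shows that a substituted aromatic ring on the sulfonamide nitrogen gave a lower number than the unsubstituted ring. Compound 3 keeps a substituted ring but neither the same substituent nor the same alkyl group, so the gain seen in compound 2 is not assured. The expected outcome is a number between those of compound 1 and compound 2, that is a modest rise, a 2.3-fold higher number from compound 2 to compound 3 (0.37 log units; beyond the scatter), because the step of a 5.0-fold lower number from compound 1 to compound 2 (0.70 log units; beyond the scatter) came from a different substituent. Compound 3 is therefore estimated at 30000 nM, with a range from 10000 nM to 90000 nM.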

Compound 3, half-maximal inhibitory concentration: 37400 nM
Compound 3: middle estimate off by 1.2-fold (0.10 log units), on the low side; low and high end bracket the measured number.
By their numbers in this assay, from the lowest: compound 2; then compounds 3 and 1 (each within the scatter of the next).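

In this assay, replacing (2-chlorophenyl)(methyl)amino with ethyl(3-methoxyphenyl)amino on the sulfonyl sulfur gives (a 2.9-fold higher number from compound 2 to compound 3 (0.47 log units; beyond the scatter)), so the gain seen with compound 2 does not carry over to this other substituted ring and larger alkyl group. Compound 3 also cannot be told apart from compound 1 (a 1.7-fold lower number from compound 1 to compound 3 (0.23 log units; within the scatter)), which shows that a substituent on the aromatic ring does not by itself set a compound apart from the unsubstituted one: among these three compounds, only compound 2 stands apart, and compound 3 goes against any general rule that ring substitution lowers the number. No supporting data offer an explanation for these differences.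

As far as these compounds go, the step to compound 3 changes the alkyl group and the ring substituent together, so the share of each stays open, and methyl(3-methoxyphenyl)amino and ethyl(2-chlorophenyl)amino would be the groups that separate them. Also open, from the compounds shown here alone, is whether the chloro group itself matters or a fluoro or methyl group would serve as well, and how a saturated amine such as piperidine would behave on the same sulfonyl sulfur.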